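From methyl to morpholin-4-yl on a carbonyl carbon

A few compounds are considered here, and "the series" means these few. Any claim that something is new, unique, unknown or untested is made for them only; others in the source may bear on it.

Measured in a functional assay on SK-OV-3 cells (Homo sapiens) for inhibition, read by ELISA, with a stated time of 24 h; a lower number here means a stronger inhibitor of growth, a higher number a weaker inhibitor of growth:
compound 1 `CN1CCN(C(=O)ONC(=O)/C=C/c2ccccc2OC(=O)c2ccccc2)CC1`: > 100000 nM
compound 2 `CC(=O)ONC(=O)/C=C/c1ccccc1OC(=O)c1ccccc1`: 16800 nM

The reading of compound 1 is a limit of the assay and not a number (the limit of > 100000 nM in this assay, at which 1 of the 2 values shown sits). Among the measured compounds shown here, compound 2 gives the only true number so far in this assay, at 16800 nM.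

The next compound, compound 3 `O=C(/C=C/c1ccccc1OC(=O)c1ccccc1)NOC(=O)N1CCOCC1`, is still to be measured. Its change is morpholin-4-yl in place of methyl on a carbonyl carbon. For the measured compounds named here, one measured step bears on this place: an at least 5.9-fold lower number from compound 1 to compound 2 (0.77 log units; beyond the scatter), with methyl in place of 4-methylpiperazin-1-yl. Read backwards, that step suggests that a ring here raises the number, though its full size remains unknown. A move towards weaker growth inhibition is therefore expected, with an estimated 3.0-fold higher number from compound 2 to compound 3 (0.47 log units; beyond the scatter). The estimate for compound 3 is 50000 nM, with an expected range of 18000 nM to 100000 nM.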

Compound 3, concentration for 50% growth inhibition: 12700 nM
The estimate for compound 3 lay 3.9-fold (0.60 log units) above the measured number; the whole stated range lies above it.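

In this assay, the morpholin-4-yl ring did not bring the rise that the earlier pair had pointed to: a 1.3-fold lower number from compound 2 to compound 3 (0.12 log units; within the scatter). A ring on this carbonyl carbon is therefore not enough on its own to weaken growth inhibition, and the weak reading belongs to 4-methylpiperazin-1-yl in particular, as this comparison of the two rings shows: an at least 7.8-fold lower number from compound 1 to compound 3 (0.89 log units; beyond the scatter). Compound 1 stands at a limit of the assay and not at a number: the limit of > 100000 nM in this assay, at which 1 of the 3 values shown sits.

On these data alone, whether piperidin-1-yl or an open-chain dimethylamino group on this carbonyl carbon would read like compound 3 or like compound 1 stays open. Also open, as far as these compounds go, is whether any group here can bring the number well under those of compound 2 and compound 3, which lie within the scatter of each other.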